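Two Aryl Piperazine Sulfonamides and an Untested Third

The source may report more compounds than this note shows. Statements on the series, on what has been measured and on what is new or still open speak of the compounds shown alone.

Compounds measured so far:
compound 1, `CCCn1c(=O)c2[nH]c(-c3ccc(S(=O)(=O)N4CCN(c5ccc(Cl)cc5)CC4)cc3)nc2n(CC)c1=O`: > 1000 nM
compound 2, `CCCn1c(=O)[nH]c2nc(-c3ccc(S(=O)(=O)N4CCN(c5cccc(F)c5)CC4)cc3)[nH]c2c1=O`: > 1000 nM

The account concerns an assay on CHO cells for displacement of a labelled ligand from adenosine receptor A3 (Homo sapiens), read by scintillation counting, with a stated time of 45 min, in the presence of a further agent that is not named here; on this read-out lower numbers stand for stronger inhibition and higher numbers for weaker inhibition. In this assay compound 1 returns only a limit, > 1000 nM. Compound 2 likewise reaches only a limit in this assay, > 1000 nM. Both measured values therefore sit at the limit of > 1000 nM in this assay, at which 2 of the 2 values shown sit, and no numbered step between measured compounds can be drawn. Compound 3, `CCCn1c(=O)[nH]c2nc(-c3ccc(S(=O)(=O)N4CCN(c5ccccc5C)CC4)cc3)[nH]c2c1=O`, has not yet been measured in this assay. It differs from compound 2 in one place: 2-methylphenyl in place of 3-fluorophenyl on an amine nitrogen in a ring. With both neighbours resting at a limit, the step in this assay cannot be read from the data, and a change within the scatter, or none at all, is the most defensible expectation. Compound 3 is accordingly expected to give about 3000 nM in this assay, in the range 1000 nM to 10000 nM. The expected step is a step that the limit leaves unreadable from compound 2 to compound 3, most likely again reported only as a limit.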

Compound 3, inhibition constant: > 1000 nM
Compound 3: only a limit was reported; the forecaster's own chance of this, stated with the estimate: 75%; the middle value lies beyond the limit too.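

Compound 3 also returns only a limit in this assay, > 1000 nM. No step from compound 2 to compound 3 can therefore be read: the limit of > 1000 nM in this assay, at which 3 of the 3 values shown sit.

The compounds shown leave open how strongly each one inhibits, and whether 2-methylphenyl and 3-fluorophenyl differ at all in this assay.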